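Arylsulfonyl aminomethyl tetralins: pyrrole in place of fluorophenyl

This account rests on a few compounds, and the source may have more. Where it says the series, first, only, none or still open, it means among the compounds named here.

Measured so far:
- compound 1 `NC[C@@H]1CCCc2cc(S(=O)(=O)c3cccc(F)c3)ccc21`: 0.0794 nM
- compound 2 `CS(=O)(=O)c1cccc(S(=O)(=O)c2ccc3c(c2)CCC[C@H]3CN)c1`: 3.98 nM

In an assay on isolated protein for displacement of a labelled ligand from 5-hydroxytryptamine receptor 6 (Homo sapiens) (on this read-out higher numbers stand for weaker inhibition and lower numbers for stronger inhibition), compound 1 gives 0.0794 nM and stands lowest of the two numbers. The difference between the two is methylsulfonyl in place of fluoro on an aromatic carbon, and compound 2 gives 3.98 nM; the step is a 50-fold higher number from compound 1 to compound 2 (1.70 log units; beyond the scatter). That single step shows that the pendant aryl group on the sulfonyl sulfur is sensitive to change in this series.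

Compound 3 `NC[C@@H]1CCCc2cc(S(=O)(=O)c3cc[nH]c3)ccc21` is not yet measured. It differs from compound 1 by 1H-pyrrol-3-yl in place of 3-fluorophenyl on a sulfonyl sulfur. Among the compounds with values here, no measured step replaces the whole aryl ring, so the only guide is the one step on that ring, a 50-fold higher number from compound 1 to compound 2 (1.70 log units; beyond the scatter), which was large and upward. A change of the ring itself is at least as far-reaching, so a step upward in this assay beyond the scatter is expected, though its size is uncertain.

Compound 3 is therefore estimated at 1 nM (range 0.15 nM to 8 nM). The expected step is a 13-fold higher number from compound 1 to compound 3 (1.10 log units; beyond the scatter).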

Compound 3, inhibition constant: 0.316 nM
The estimate for compound 3 lay 3.2-fold (0.50 log units) above the measured number; measured number inside the range.
By their numbers in this assay, from the lowest: compound 1; then compound 3; then compound 2.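

Within the data shown here, exchanging the whole ring on the sulfonyl sulfur gives only a 4.0-fold higher number from compound 1 to compound 3 (0.60 log units; beyond the scatter) in this assay, a modest step, whereas the single substituent change on the phenyl ring gave a 50-fold higher number from compound 1 to compound 2 (1.70 log units; beyond the scatter) and was large. This position therefore does not require a six-membered aromatic ring of carbon only or a fluorine: with 1H-pyrrol-3-yl, which is smaller and carries a hydrogen-bond donor, compound 3 still gives 0.316 nM and keeps most of the strength of compound 1. Nothing available accounts for the step, and its share from ring size, from the loss of fluorine and from the added donor cannot be separated.

Still open, as far as these compounds go, is what the hydrogen on the pyrrole nitrogen contributes, which a 1-methyl-1H-pyrrol-3-yl group or a thiophen-3-yl or furan-3-yl ring on the same sulfonyl sulfur would address. Also open, from the compounds shown here alone, is whether the ring tolerates other substituents, since an unsubstituted phenyl, a 3-chlorophenyl or a 3-methoxyphenyl would show whether the step from fluoro to methylsulfonyl reflects that one group alone.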